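A Methyl Group Where Compound 3 Has Hydrogen

A few compounds are considered here, and "the series" means these few. Any claim that something is new, unique, unknown or untested is made for them only; others in the source may bear on it.

Compound 1 `CCCc1nc(-c2ccccc2)c(CNCCN2CCN(c3ccccc3Cl)CC2)o1`: 4370 nM
Compound 2 `CCCc1nc(-c2ccccc2)c(CNCCN2CCN(c3cccc(C(F)(F)F)c3)CC2)o1`: 1940 nM
Compound 3 `CCCc1nc(-c2ccccc2)c(CNCCN2CCN(c3ccccc3)CC2)o1`: 10300 nM

Among these three, compound 3 gives the highest number in an assay on HEK293 cells for inhibition of Voltage-dependent T-type calcium channel subunit alpha-1G (Homo sapiens), read by patch clamp (on this read-out higher numbers stand for weaker inhibition and lower numbers for stronger inhibition), so it is the weakest inhibitor of the set. Compound 4 `CCCc1nc(-c2ccccc2)c(CNCCN2CCN(c3ccccc3C)CC2)o1` differs from it by one change: methyl in place of hydrogen on an aromatic carbon. Among the measured compounds shown here, two measured steps bear on this. Taking away chloro gave a 2.4-fold higher number from compound 1 to compound 3 (0.37 log units; beyond the scatter), and taking away trifluoromethyl gave a 5.3-fold higher number from compound 2 to compound 3 (0.73 log units; beyond the scatter); in both, the bare phenyl carried the higher number. A methyl is neither of those groups, so only a modest step toward a lower number is expected: a 2.1-fold lower number from compound 3 to compound 4 (0.31 log units; beyond the scatter). Compound 4 is therefore estimated at 5000 nM, with a range from 2500 nM to 10000 nM.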

Compound 4, half-maximal inhibitory concentration: 4300 nM
Beside the measured number, compound 4's estimate is 1.2-fold (0.07 log units) above it; the measured number falls inside the stated range.
By their numbers in this assay, from the lowest: compound 2; then compounds 4 and 1 (each within the scatter of the next); then compound 3.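

Adding methyl to the bare phenyl gives a 2.4-fold lower number from compound 3 to compound 4 (0.38 log units; beyond the scatter) so the group on this carbon, ortho to a large group, need not be chloro for the number to drop. Chloro and methyl at this place cannot be told apart, with a 1.0-fold lower number from compound 1 to compound 4 (0.01 log units; within the scatter) as their step. The 3-(trifluoromethyl)phenyl of compound 2 keeps its lead over 2-methylphenyl, with a 2.2-fold higher number from compound 2 to compound 4 (0.35 log units; beyond the scatter) as the step between them.

On these data alone, whether a larger group such as ethyl or methoxy on this same carbon would lower the number further stays open. Nothing here gives a measured reason for any of these steps.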